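A few compounds are considered here, and "the series" means these few. Any claim that something is new, unique, unknown or untested is made for them only; others in the source may bear on it.

Measured in a functional assay on THP-1 cells (Homo sapiens) for cytotoxicity, read by MTT assay, with a stated time of 24 h; on this read-out higher numbers stand for weaker inhibition and lower numbers for stronger inhibition:
- compound 1 `COc1ccc(/C=C2\CN(C)C/C(=C\c3ccccc3F)C2=O)cc1`: 15400 nM
- compound 2 `CN1C/C(=C\c2ccc(C#N)cc2)C(=O)/C(=C/c2ccccc2F)C1`: 810 nM

Of these two compounds, the lowest number belongs to compound 2 at 810 nM. The next structure is compound 3 `CN1C/C(=C\c2ccc(C#N)cc2)C(=O)/C(=C/c2ccc(Cl)cc2Cl)C1`, which is still unmeasured. It differs by one group: 2,4-dichlorophenyl in place of 2-fluorophenyl on a double-bonded chain carbon bound to a double-bonded ring carbon. In words, 2,4-dichlorophenyl stands in place of 2-fluorophenyl on a double-bonded chain carbon bound to a double-bonded ring carbon.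

Going by the values given here, only one measured step is available: a 19-fold lower number from compound 1 to compound 2 (1.28 log units; beyond the scatter). That large step came from cyano in place of methoxy on an aromatic carbon, a different change from this one. Among the compounds with values here, no measured pair shows what a change at this place does, so no step beyond the scatter is expected in this assay, and no direction can be firmly expected. The estimated step is a 1.2-fold lower number from compound 2 to compound 3 (0.10 log units; within the scatter). The estimated value for compound 3 is 650 nM, with an expected range from 200 nM to 2000 nM.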

Compound 3, half-maximal inhibitory concentration: 1910 nM
For compound 3 the middle estimate is 2.9-fold (0.47 log units) below the measured one, within the range that was stated.
By their numbers in this assay, from the lowest: compound 2; then compound 3; then compound 1.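

In this assay, putting 2,4-dichlorophenyl in place of 2-fluorophenyl on a double-bonded chain carbon bound to a double-bonded ring carbon gives a 2.4-fold higher number from compound 2 to compound 3 (0.37 log units; beyond the scatter), so this position also affects the read-out. The direction is towards weaker inhibition, and the step is modest, whereas the earlier change on the other aromatic ring, a 19-fold lower number from compound 1 to compound 2 (1.28 log units; beyond the scatter), was large and went towards stronger inhibition. Nothing available explains why the number rose at this position.

This single swap removes fluorine and adds two chlorine atoms at once, leaving open which part of the change moves the number. Also open, as far as these compounds go, is how the position would respond to a plain phenyl group, or to a phenyl ring carrying an amine or a carboxylic acid.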